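The source may hold more compounds than are shown below. What is called first, only, known or untested is meant among the compounds shown, and "the series" means these compounds.

Compound 1 `Nc1ccccc1NC(=O)c1ccc(CSC(=S)N2CCN(c3ccc(Cl)cc3)CC2)cc1` — 44.8%
Compound 2 `Nc1ccccc1NC(=O)c1ccc(CSC(=S)N2CCN(c3cccnc3)CC2)cc1` — 72.5%
Compound 3 `CC1CCCCN1C(=S)SCc1ccc(C(=O)Nc2ccccc2N)cc1` — 76.3%

Of the compounds shown here, three sharing one core have been measured in a functional assay on HeLa cells (Homo sapiens) for antiproliferative activity, read by CCK-8 assay, with a stated time of 72 h, tested at 8 uM; a higher number here means a stronger effect of the compound at the concentration tested, a lower number a weaker effect. Compound 2 stands second of the three: compound 3 gives 76.3%, within the scatter of compound 2, while compound 1 gives 44.8%, well below it. The unmeasured compound 4 `N#Cc1ccc(N2CCN(C(=S)SCc3ccc(C(=O)Nc4ccccc4N)cc3)CC2)cc1` differs from compound 2 at one point: 4-cyanophenyl in place of pyridin-3-yl on an amine nitrogen in a ring. For the measured compounds named here, one measured step bears on this change, a number 27.7 percentage points higher from compound 1 to compound 2 (beyond the scatter), in which a 4-chlorophenyl gave way to the very pyridin-3-yl that compound 4 now loses. Since compound 4 carries a carbon-only aromatic ring on that nitrogen again, as compound 1 does at 44.8%, a step back in that direction is expected, though a nitrile is not a chlorine and the size is uncertain. Compound 4 is therefore estimated at 55%, within 35% to 75%, an expected a number 17.5 percentage points lower from compound 2 to compound 4 (beyond the scatter).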

Compound 4, a percentage reported as inhibition, at one concentration (the size of the read-out at that concentration, not a potency): 70.6%
Beside the measured number, compound 4's estimate is 15.6 percentage points below it; the range from low to high includes it.
By their numbers in this assay, from the lowest: compound 1; then compounds 4, 2 and 3 (each within the scatter of the next).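

In this assay, an aromatic ring of carbon only on this amine nitrogen does not by itself lower the read-out: 4-cyanophenyl in place of pyridin-3-yl gives a number 1.9 percentage points lower from compound 2 to compound 4 (within the scatter). Compound 1 carries such a ring too, and its value is low. Cyano in place of chloro on an aromatic carbon gives a number 25.8 percentage points higher from compound 1 to compound 4 (beyond the scatter). Nothing measured here accounts for this difference between cyano and chloro.

From the compounds shown here alone, it remains open whether a plain phenyl, or a phenyl carrying an amine or a carboxylic acid in place of the nitrile, would stay level with compound 4 or sit nearer compound 1. A single concentration also leaves the potencies of these compounds open.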